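The compounds below may be only part of what the source reports. "The series", "measured", "known", "first", "only" and "open" are said of these compounds alone.

Of the compounds shown here, three built on one shared core have been tested in a functional assay on DU-145 cells (Homo sapiens) for cytotoxicity, read by MTT assay, with a stated time of 48 h; a lower number here means a stronger inhibitor, a higher number a weaker inhibitor. Compound 1 `COc1ccc(-c2cc(C(=O)Nc3nc4ccccc4s3)nc3cc(-c4ccccc4)nn23)cc1` gives 2950 nM in this assay. Compound 2 `COc1ccc(-c2cc(C(=O)Nc3nc4ccccc4s3)nc3cc(-c4ccccc4)nn23)cc1OC` differs from compound 1 by methoxy in place of hydrogen on an aromatic carbon, and in this assay compound 2 gives 19100 nM; that single change produced a 6.5-fold higher number from compound 1 to compound 2 (0.81 log units; beyond the scatter). Compound 3 `COc1ccc(-c2cc(C(=O)Nc3nc4cc(C)c(C)cc4s3)nc3cc(-c4ccccc4)nn23)cc1OC` keeps the methoxy pattern of compound 2 but carries a 5,6-dimethyl-1,3-benzothiazol-2-yl group in place of the 1,3-benzothiazol-2-yl group on the amide-type nitrogen, and in this assay compound 3 gives 6910 nM, which amounts to a 2.8-fold lower number from compound 2 to compound 3 (0.44 log units; beyond the scatter). Compound 3 and compound 1 differ in more than one place, so the difference between the two cores is not broken down here; their values show that compound 3 gives a higher number than compound 1.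

Compound 4 `COc1cc(-c2cc(C(=O)Nc3nc4cc(C)c(C)cc4s3)nc3cc(-c4ccccc4)nn23)cc(OC)c1OC` has not yet been measured. It differs from compound 3 by methoxy in place of hydrogen on an aromatic carbon. This is the same kind of change as that from compound 1 to compound 2, not the same: in compound 4 the entering methoxy is also meta to a methoxy group, a neighbour the earlier change did not have. Because the earlier change gave a 6.5-fold higher number from compound 1 to compound 2 (0.81 log units; beyond the scatter), a rise in the number is expected here too, though the different surroundings leave room for a smaller one. The expected step is a 2.6-fold higher number from compound 3 to compound 4 (0.42 log units; beyond the scatter). In this assay compound 4 is expected to give about 18000 nM, with a likely range from 6000 nM to 50000 nM.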

Compound 4, half-maximal inhibitory concentration: 3710 nM
Estimate against measurement, compound 4: 4.9-fold (0.69 log units) above; measured number below the stated range.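

In this assay, going from 3,4-dimethoxyphenyl to 3,4,5-trimethoxyphenyl gives a 1.9-fold lower number from compound 3 to compound 4 (0.27 log units; within the scatter), so this added methoxy leaves no difference that can be told apart from ordinary repeat-to-repeat variation. Adding a methoxy to the aromatic ring therefore did not have a transferable effect in this small series, as the two steps clearly disagree: the same change on two cores in this assay, a 6.5-fold higher number (0.81 log units; beyond the scatter) from compound 1 to compound 2 and a 1.9-fold lower number (0.27 log units; within the scatter) from compound 3 to compound 4, 12-fold (1.08 log units) apart, beyond the scatter of two such steps

This comparison shows that the result of the earlier step cannot simply be carried over to another core, but it does not show what makes the two cases differ, since the second case has both the 5,6-dimethyl-1,3-benzothiazol-2-yl group on the amide-type nitrogen and an entering methoxy that is meta to a methoxy group, and these two features cannot be separated here.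

The compounds shown leave open how the 3,4,5-trimethoxyphenyl group behaves alongside the 1,3-benzothiazol-2-yl group without its two methyl groups, a pairing that would help separate those two features. Also open, going by these compounds, is what a hydroxy group or an amine would do in place of the entering methoxy on this aromatic ring.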